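The source may hold more compounds than are shown below. What is called first, only, known or untested is meant among the compounds shown, and "the series" means these compounds.

Compound 2 `CC(C)NC(=O)c1nc(NCc2cccnc2)nc2ccsc12` belongs to a pair built on one shared core; its companion, compound 1 `O=C(c1ccc(Cl)s1)c1nc(NCc2cccnc2)nc2ccsc12`, differs from it only in the group on the carbonyl carbon. In a functional assay on CHO-K1 cells for antagonist activity at adenosine receptor A2b (Homo sapiens), read by FLIPR and calcium flux (on this read-out lower numbers stand for stronger inhibition and higher numbers for weaker inhibition), compound 1 gives 487 nM, and in this assay compound 2 gives 309 nM. For the measured compounds named here, the single measured step, a 1.6-fold lower number from compound 1 to compound 2 (0.20 log units; within the scatter), stays within the scatter, so compound 2 holds the lower of the two numbers without a difference that can be called real.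

Compound 3 `O=C(NC1CC1)c1nc(NCc2cccnc2)nc2ccsc12` keeps the carbamoyl group of compound 2 and alters only its substituent: cyclopropyl in place of isopropyl on an amide-type nitrogen. Going by the values given here, no measured step touches this position; the one step in hand concerns the carbonyl carbon and is itself within the scatter, so it offers no direction for the amide-nitrogen change. With both groups of the same size and carbon only, nothing in the record argues for a shift beyond the scatter in this assay.

Compound 3 is therefore expected to give about 300 nM, with a range from 120 nM to 800 nM. The step this estimate implies, a 1.0-fold lower number from compound 2 to compound 3 (0.01 log units; within the scatter), is expected to stay within the scatter.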

Compound 3, half-maximal inhibitory concentration: 256 nM
For compound 3 the middle estimate is 1.2-fold (0.07 log units) above the measured one; the measured number falls inside the stated range.
By their numbers in this assay, from the lowest: compounds 3, 2 and 1 (each within the scatter of the next).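

Cyclopropyl in place of isopropyl on an amide-type nitrogen gives the first reading at this position: in this assay the change amounts to a 1.2-fold lower number from compound 2 to compound 3 (0.08 log units; within the scatter), so exchanging one three-carbon group for another that carries a three-membered ring leaves compound 2 and compound 3 indistinguishable. The wider comparison, a 1.9-fold lower number from compound 1 to compound 3 (0.28 log units; within the scatter), is also within the scatter, so cyclopropylamino and 5-chlorothiophen-2-yl on a carbonyl carbon cannot be told apart here, and all three compounds read as a single level. Nothing available bears on the reason for this result.

On these data alone, the groups on the amide-type nitrogen in these compounds are limited to isopropyl and cyclopropyl, so it remains open whether a longer chain, a cyclohexyl ring, or a chain ending in an amine or a carboxylic acid would move the number beyond the scatter. As far as these compounds go, it is also open whether replacing the amide hydrogen with a methyl group, leaving the nitrogen with two carbon substituents, would change the reading in this assay.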